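Moving the fluorines on the benzoyl ring of compound 1

The compounds below may be only part of what the source reports. "The series", "measured", "known", "first", "only" and "open" are said of these compounds alone.

Among the compounds with values here, compound 1 `O=C(c1ccc(F)cc1)N1CCc2nc(COc3cccc(F)c3)oc2C1` is, in a functional assay on HEK293 cells for positive allosteric modulation of metabotropic glutamate receptor 5 (Homo sapiens), read by calcium flux (a higher number here means a larger maximal response, a lower number a smaller maximal response), the higher of the two measured compounds at 78%; compound 2 `O=C(c1ccc(F)cc1)N1CCc2nc(COc3ccc(F)c(F)c3)oc2C1` gives 40%, and the only measured step, a number 38 percentage points lower from compound 1 to compound 2 (beyond the scatter), concerns the other aromatic ring. Compound 3 `O=C(c1cc(F)cc(F)c1)N1CCc2nc(COc3cccc(F)c3)oc2C1` differs from compound 1 by 3,5-difluorophenyl in place of 4-fluorophenyl on a carbonyl carbon. Within the data shown here, no measured step touches this ring, so the step from compound 2 is only a loose guide and the direction remains open. Compound 3 is therefore expected, with wide uncertainty, to show 60% (range 30% to 95%), a change of a number 18 percentage points lower from compound 1 to compound 3 (beyond the scatter).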

Compound 3, largest response reached (reported as percent of maximum), in percent of the reference or control that the assay uses: 42%
Compound 3: middle estimate off by 18 percentage points, on the high side; the range from low to high includes it.
By their numbers in this assay, from the lowest: compounds 2 and 3 (each within the scatter of the next); then compound 1.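

Changing the group on the carbonyl carbon turns out to matter in this assay: 3,5-difluorophenyl in place of 4-fluorophenyl gives a number 36 percentage points lower from compound 1 to compound 3 (beyond the scatter) on this ring, which the earlier step left untouched. Both single changes from compound 1 on either aromatic ring now lower the response. Nothing measured explains this drop. As far as these compounds go, it remains open whether the drop reflects losing 4-fluorophenyl or gaining 3,5-difluorophenyl, and how a plain phenyl, a 4-chlorophenyl or a pyridine ring would behave on that carbonyl carbon.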